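Benzyl in place of phenyl on the shared core

The source may report more compounds than this note shows. Statements on the series, on what has been measured and on what is new or still open speak of the compounds shown alone.

Compound 1 `Cc1cc(Nc2nc(NC3CCNC3)nc3[nH]ncc23)n[nH]1`: 1050 nM
Compound 2 `Cc1cc(Nc2nc(Nc3ccccc3)nc3[nH]ncc23)n[nH]1`: 5900 nM

Both measured compounds were tested in an assay on isolated protein for inhibition of serine/threonine-protein kinase PAK 4 (Homo sapiens), read by HTRF, with a stated time of 60 min; on this read-out higher numbers stand for weaker inhibition and lower numbers for stronger inhibition. Compound 2 stands highest of the two numbers; its nearest neighbour is compound 1, whose value is the lower of the pair. Going by the values given here, the one measured step, a 5.6-fold higher number from compound 1 to compound 2 (0.75 log units; beyond the scatter), concerns phenyl in place of pyrrolidin-3-yl on a nitrogen on an aromatic ring and was modest.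

Compound 3 `Cc1cc(Nc2nc(NCc3cccc(Br)c3)nc3[nH]ncc23)n[nH]1` has not yet been measured. It differs from compound 2 by 3-bromobenzyl in place of phenyl on a nitrogen on an aromatic ring. Among the compounds with values here, no measured step compares a benzyl with a phenyl here, so the single step from compound 1 to compound 2 bears on it only loosely. Compound 3 is therefore expected to sit near compound 2, with at most a small change; the step of a 2.0-fold lower number from compound 2 to compound 3 (0.29 log units; within the scatter) is the estimate. For compound 3 the estimate in this assay is 3000 nM, ranging from 800 nM to 12000 nM.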

Compound 3, half-maximal inhibitory concentration: 4340 nM
Compound 3: middle estimate off by 1.4-fold (0.16 log units), on the low side; the range from low to high includes it.
By their numbers in this assay, from the lowest: compound 1; then compounds 3 and 2 (each within the scatter of the next).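

On the nitrogen on an aromatic ring, exchanging phenyl for 3-bromobenzyl gives a 1.4-fold lower number from compound 2 to compound 3 (0.13 log units; within the scatter) in this assay, so this larger group, with its added bromine, leaves the number indistinguishable from that of compound 2. Set against pyrrolidin-3-yl, the same group gives a 4.1-fold higher number from compound 1 to compound 3 (0.62 log units; beyond the scatter), so both groups carrying a six-membered aromatic ring of carbon only now stand apart from compound 1, which has the lowest number of the three. No evidence here accounts for either step.

The compounds shown leave open whether plain benzyl, or phenyl bearing bromine, would behave like these two groups. They also leave open whether a piperidin-4-yl group or a benzyl carrying an amine would match compound 1 or move the number lower still.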